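Swapping a benzyloxy for a carboxymethoxyphenyl arm

This account rests on a few compounds, and the source may have more. Where it says the series, first, only, none or still open, it means among the compounds named here.

Measured compounds:
compound 1 `COc1ccc(C(c2ccc(OC(C)CN(C)C)cc2)c2cccc3ccccc23)c(OC)c1OC` – 13100 nM
compound 2 `COc1ccc(C(OCc2ccccc2)c2cccc3ccccc23)c(OC)c1OC` – 14100 nM

In a functional assay on MCF7 cells (Homo sapiens) for inhibition, read by sulforhodamine B assay, with a stated time of 48 h (a higher number here means a weaker inhibitor, a lower number a stronger inhibitor), compound 2 gives 14100 nM, the higher of the two numbers in hand, yet its nearest neighbour, compound 1, at 13100 nM, sits within the scatter of it, so the two are indistinguishable on these data. Among the compounds with values here, no step between measured compounds is available, and the two measured compounds differ in more than one place, so their comparison alone cannot be read as a step.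

Compound 3 `COc1ccc(C(c2ccc(OCC(=O)O)cc2)c2cccc3ccccc23)c(OC)c1OC` is not yet measured. It differs from compound 2 by 4-(carboxymethoxy)phenyl in place of benzyloxy on a saturated chain carbon bound to two aromatic carbons. The arm that enters makes compound 3 resemble compound 1, which gives 13100 nM, more closely than compound 2 does, though the chain on that arm is a different one. With both measured compounds weak and close together, no large movement is expected; the step from compound 2 to compound 3 is estimated to be a 1.4-fold higher number from compound 2 to compound 3 (0.15 log units; within the scatter), at most modest and possibly within the scatter. Compound 3 is therefore expected to give about 20000 nM in this assay, with a range of 6000 nM to 60000 nM.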

Compound 3, half-maximal inhibitory concentration: > 20000 nM
Compound 3 was reported as a limit (the forecaster's own chance of this, stated with the estimate: 20%); the middle value lies on the limit itself.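

In this assay, compound 3 stands at a limit of the assay and not at a number: the limit of > 20000 nM in this assay, at which 1 of the 3 values shown sits.

This gives the series its first readable steps: 4-(carboxymethoxy)phenyl in place of benzyloxy on a saturated chain carbon bound to two aromatic carbons gives an at least 1.4-fold higher number from compound 2 to compound 3 (0.15 log units; that floor lies within the scatter), and carboxymethyl in place of 1-((dimethylamino)methyl)ethyl on an oxygen on an aromatic ring gives an at least 1.5-fold higher number from compound 1 to compound 3 (0.18 log units; that floor lies within the scatter). Both swaps therefore point the same way, with neither yielding a lower number in this assay, although each floor lies within the scatter and so neither step can be called a real loss.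

Within the data shown here, how far compound 3 truly lies from compound 1 and compound 2 stays open, as the limit gives a floor and no size for either step. Also open, on these data alone, is whether the carboxymethyl chain itself or its carboxylic acid sets this result, which a methyl ester on the same arm, or an amine on a chain of the same length, would help to separate.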